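A few compounds are considered here, and "the series" means these few. Any claim that something is new, unique, unknown or untested is made for them only; others in the source may bear on it.

Measured in a functional assay on Vero cells (Chlorocebus sabaeus) for cytotoxicity; on this read-out higher numbers stand for weaker inhibition and lower numbers for stronger inhibition:
- compound 1 `Nc1ccn([C@H]2C=C(F)[C@@H](CO)O2)c(=O)n1`: > 100000 nM (a limit)
- compound 2 `Nc1nc(=O)n([C@H]2C=C(F)[C@@H](CO)O2)cc1F`: > 100000 nM (a limit)
- compound 3 `Nc1nc(O)c2ncn([C@H]3C=C(F)[C@@H](CO)O3)c2n1`: 75500 nM

Compound 1 has no exact number, and stands at the limit of > 100000 nM in this assay, at which 2 of the 3 values shown sit. Compound 4 `Nc1ccn([C@@H]2C=C(F)[C@H](CO)O2)c(=O)n1` is its mirror image: the two compounds have the same atoms and bonds and differ only in configuration as drawn: 2 of 2 stereo elements differ (all stereocentres are inverted: mirror images); a stereocentre at a saturated ring carbon is drawn R in compound 1 and S in compound 4; a stereocentre at a saturated ring carbon is drawn R in compound 1 and S in compound 4. Within the data shown here, the one measured step, a step that the two limits leave unreadable from compound 1 to compound 2, has no readable size and swaps a group rather than changing configuration. Among the measured compounds shown here, no mirror-image pair has been measured, so no measured step gives the size of this change. For the measured compounds named here, the only number is from compound 3 at 75500 nM, which still lies at the weak end of this assay. The expected change is therefore none beyond the scatter, with a number no higher from compound 1 to compound 4 (the limit leaves the size open) as the estimate. Compound 4 is expected at 100000 nM, with an estimated range of 25000 nM to 150000 nM.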

Compound 4, half-maximal inhibitory concentration: > 100000 nM
Compound 4 ended at the assay's limit; the forecaster's own chance of this, stated with the estimate: 70%; the middle value lies on the limit itself.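

Compound 1 and compound 4 are mirror images, and both sit at a limit, so the step between them cannot be read: the limit of > 100000 nM in this assay, at which 3 of the 4 values shown sit.

As far as these compounds go, whether inverting both stereocentres changes the result in this assay at all stays open.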